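The compounds below may be only part of what the source reports. "The series", "measured", "known", "first", "only" and "open" are said of these compounds alone.

In a physicochemical assay for solubility, read by HPLC, with a stated time of 24 h (a lower number here means a less soluble compound, a higher number a more soluble compound), compound 3 `CC(C)(C)c1[nH]cnc1/C=c1\[nH]c(=O)/c(=C/c2cccc(C(=O)c3cccnc3)c2)[nH]c1=O` gives < 0.1 ug/mL, which is a limit and not a number. Compound 1 `CC(C)(C)c1[nH]cnc1/C=c1\[nH]c(=O)/c(=C/c2cccc(C(=O)c3ccccc3)c2)[nH]c1=O`, with phenyl on the carbonyl carbon, gives < 0.1 ug/mL, also a limit. Compound 2 `CC(C)(C)c1[nH]cnc1/C=c1\[nH]c(=O)/c(=C/c2cccc(C(=O)N3CCC3)c2)[nH]c1=O`, with azetidin-1-yl there, gives 4.23 ug/mL. Compound 4 `CC(C)(C)c1[nH]cnc1/C=c1\[nH]c(=O)/c(=C/c2cccc(C(=O)c3ccsc3)c2)[nH]c1=O` has thiophen-3-yl in place of pyridin-3-yl on a carbonyl carbon. The nearest measured swap of one aromatic ring for another is a step that the two limits leave unreadable from compound 1 to compound 3. The large steps, an at least 42-fold higher number from compound 1 to compound 2 (1.62 log units; beyond the scatter) and an at least 42-fold lower number from compound 2 to compound 3 (1.62 log units; beyond the scatter), both involve azetidin-1-yl, which plays no part in this change. The expected step is therefore small, a step that the limit leaves unreadable from compound 3 to compound 4, with no move beyond the scatter foreseen in either direction. For compound 4 the estimated value is 0.08 ug/mL, with an expected range of 0.03 ug/mL to 0.3 ug/mL.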

Compound 4, solubility: < 0.1 ug/mL
Compound 4: a limit, no number; the forecaster's own chance of this, stated with the estimate: 85%; the middle value is on the limit's open side.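

Compound 4, with thiophen-3-yl on the carbonyl carbon, also ends at a limit in this assay, so a five-membered aromatic ring joins the two six-membered ones at the same limit: the limit of < 0.1 ug/mL in this assay, at which 3 of the 4 values shown sit. The steps among compound 1, compound 3 and compound 4 cannot be read. Thiophen-3-yl in place of azetidin-1-yl gives an at least 42-fold lower number from compound 2 to compound 4 (1.62 log units; beyond the scatter), so the large gap seen with phenyl and pyridin-3-yl also holds for this third aromatic ring.

From the compounds shown here alone, how these three aromatic compounds truly compare stays open. Also open, going by these compounds, is how an amine, a carboxylic acid or a longer chain on the carbonyl carbon would compare with azetidin-1-yl.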